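The source may hold more compounds than are shown below. What is called first, only, known or untested is meant among the compounds shown, and "the series" means these compounds.

Two compounds share a core built from indole-bearing portions joined around a nitrile-carrying carbon, and differ only in the group attached to the amide carbonyl. Compound 1 `COc1ccc(C(=O)NC[C@H]2c3[nH]c4ccccc4c3C[C@H]3[C@H]4c5[nH]c6ccccc6c5C[C@@H]([C@H](C#N)N23)N4C)cc1` carries a 4-methoxyphenyl there and in a functional assay on HepG2 cells (Homo sapiens) for cytotoxicity, read by MTT assay, with a stated time of 72 h (on this read-out higher numbers stand for weaker inhibition and lower numbers for stronger inhibition), compound 1 gives 310 nM. Compound 2 `CN1[C@@H]2c3[nH]c4ccccc4c3C[C@H]1[C@H](C#N)N1[C@@H](CNC(=O)c3cc4ccccc4o3)c3[nH]c4ccccc4c3C[C@@H]21` carries a 1-benzofuran-2-yl instead, and in this assay compound 2 gives 280 nM. Among the measured compounds shown here, the single measured step, a 1.1-fold lower number from compound 1 to compound 2 (0.04 log units; within the scatter), did not move the number beyond the scatter, so compound 2 has the lower of the two values without being separable from compound 1.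

Compound 3 `CN1[C@@H]2c3[nH]c4ccccc4c3C[C@H]1[C@H](C#N)N1[C@@H](CNC(=O)/C=C/c3cccc(C(F)(F)F)c3)c3[nH]c4ccccc4c3C[C@@H]21` changes the same position again: 2-(3-(trifluoromethyl)phenyl)ethenyl in place of 1-benzofuran-2-yl on a carbonyl carbon. For the measured compounds named here, the entering group is larger than the one it replaces and brings a double bond outside the aromatic ring, but the only comparison at this position, from compound 1 to compound 2, showed no effect beyond the scatter, and no step shows how a trifluoromethyl-bearing or alkene-containing group behaves here. The expectation is therefore a step in this assay of a 1.1-fold higher number from compound 2 to compound 3 (0.03 log units; within the scatter), that is, no change beyond the scatter. Compound 3 is estimated in this assay at 300 nM, with a range from 100 nM to 900 nM.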

Compound 3, half-maximal inhibitory concentration: 540 nM
Compound 3: the middle estimate sits 1.8-fold (0.26 log units) below what was measured; low and high end bracket the measured number.
By their numbers in this assay, from the lowest: compounds 2, 1 and 3 (each within the scatter of the next).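

At the place on the carbonyl carbon, the shared core now carries a third type of group, 2-(3-(trifluoromethyl)phenyl)ethenyl, with one six-membered aromatic ring and a double bond outside aromatic rings. In this assay replacing 1-benzofuran-2-yl with this group gives a 1.9-fold higher number from compound 2 to compound 3 (0.29 log units; within the scatter) and replacing 4-methoxyphenyl with it gives a 1.7-fold higher number from compound 1 to compound 3 (0.24 log units; within the scatter) and so neither step separates compound 3 from the compounds before it, although the entering group has 12 heavy atoms against 9 for the 1-benzofuran-2-yl. All three groups therefore sit within the scatter of one another at this place, and nothing measured here gives a reason for the small gaps between their numbers.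

The trifluoromethyl group and the double bond enter together in compound 3, so the compounds shown cannot tell what either does alone. Every group shown at this place holds an aromatic ring, which leaves open whether a group without one, such as an amine, a carboxylic acid or a longer saturated chain, would shift the number beyond the scatter.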